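The source may report more compounds than this note shows. Statements on the series, on what has been measured and on what is new or still open speak of the compounds shown alone.

Working notes on the series. Compound 1 `CS/C(=N\C(=O)c1ccno1)NC(=O)c1ccno1` carries a methyl group on sulfur in the shared core. In an ADME assay on MCF-10A cells (Homo sapiens) for cytotoxicity, read by MTT assay, with a stated time of 72 h (on this read-out lower numbers stand for stronger inhibition of growth and higher numbers for weaker inhibition of growth), compound 1 returns only the limit > 100000 nM. Compound 2 `C[Se]/C(=N\C(=O)c1cccs1)NC(=O)c1cccs1` carries a methyl group on selenium with a different amide core. In this assay compound 2 gives 41100 nM. Compound 3 `O=C(/N=C(/NC(=O)c1ccno1)[Se]Cc1ccccc1)c1ccno1` carries a benzyl group on selenium in the core of compound 1. In this assay compound 3 also returns only the limit > 100000 nM. Compound 3 thus stands at the top of the range shown, beside compound 1, with compound 2 the only member that gives a number. The step that the two limits leave unreadable from compound 1 to compound 3 cannot be sized because the limit of > 100000 nM in this assay, at which 2 of the 3 values shown sit, covers both of its ends.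

Compound 4 `C[Se]/C(=N\C(=O)c1ccno1)NC(=O)c1ccno1` is not yet measured. It differs from compound 3 by hydrogen in place of phenyl on a saturated chain carbon bound to a selenium atom, which read one bond further out is benzyl to methyl. Among the compounds with values here, no measured step covers this change; the one step that touches the substituent on selenium, from compound 1 to compound 3, is unreadable, and the values of compounds 1 and 3 give no sign that this position moves the read-out. Compound 4 is therefore expected to sit near the limit, with an estimated step of an at least 1.1-fold lower number from compound 3 to compound 4 (0.04 log units; that floor lies within the scatter) not expected to exceed the scatter. For compound 4 the estimate is 90000 nM, within 35000 nM to 250000 nM.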

Compound 4, concentration for total growth inhibition: 15400 nM
Compound 4: the middle estimate sits 5.8-fold (0.77 log units) above what was measured; measured number outside the range, below it.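

Unlike the unreadable pair of compound 1 and compound 3, the new value shows that the group on selenium moves the read-out in this assay: hydrogen in place of phenyl on a saturated chain carbon bound to a selenium atom, which is benzyl to methyl, gives an at least 6.4-fold lower number from compound 3 to compound 4 (0.81 log units; beyond the scatter). Within the data shown here, with the core of compound 1 kept, the atom that carries the methyl group also matters, as selenium in place of sulfur gives an at least 6.4-fold lower number from compound 1 to compound 4 (0.81 log units; beyond the scatter), a change that no earlier pair could size. Both steps are floors and not full sizes, because each starts from a compound that returns only a limit: the limit of > 100000 nM in this assay, at which 2 of the 4 values shown sit.

The compounds shown leave open how the read-out runs between methyl and benzyl on selenium, for instance with an ethyl group or a longer chain, and what an amine or a carboxylic acid at the end of such a chain would do. Also open, from the compounds shown here alone, is whether selenium in place of sulfur gives a similar step in the amide core of compound 2.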